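Ether side chain and microsomal clearance in the series

The source may hold more compounds than are shown below. What is called first, only, known or untested is meant among the compounds shown, and "the series" means these compounds.

Measured so far in an ADME assay on microsomes from liver (Homo sapiens) for metabolic stability, read by LC-MS, tested at 1 uM; on this read-out higher numbers stand for fast clearance and lower numbers for slow clearance:
compound 1 `OC1(COc2ccc([C@H]3CC[C@]4(CC3)OOC3(O4)C4CC5CC(C4)CC3C5)cc2)CCNCC1` — 16 mL.min-1.g-1
compound 2 `c1cc([C@H]2CC[C@]3(CC2)OOC2(O3)C3CC4CC(C3)CC2C4)ccc1OCCC1CCNCC1` — a limit only, < 7 mL.min-1.g-1
compound 3 `c1cc([C@H]2CC[C@]3(CC2)OOC2(O3)C3CC4CC(C3)CC2C4)ccc1OC1CCNCC1` — 15 mL.min-1.g-1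

Compound 3 and compound 1 sit within the scatter of each other (a 1.1-fold lower number from compound 1 to compound 3 (0.03 log units; within the scatter)), so no order between them is claimed. For compound 2 this assay reports only a limit, not a number. Compound 4 `O[C@H]1CC[C@H](NCCCOc2ccc([C@H]3CC[C@]4(CC3)OOC3(O4)C4CC5CC(C4)CC3C5)cc2)CC1` differs from compound 3 by 3-((4-hydroxycyclohexyl)amino)propyl in place of piperidin-4-yl on an oxygen on an aromatic ring. Of the measured steps, an at least 2.1-fold higher number from compound 2 to compound 3 (0.33 log units; beyond the scatter) bears most directly on this change, the extended chain on the oxygen going with the lower reading; an at least 2.2-fold lower number from compound 1 to compound 2 (0.35 log units; beyond the scatter) points the same way. Going by the values given here, a modest lowering is therefore expected for compound 4, a 1.7-fold lower number from compound 3 to compound 4 (0.22 log units; within the scatter), with a wide range kept since the entering group has no measured counterpart here. Compound 4 is estimated at 9 mL.min-1.g-1 (range 4 mL.min-1.g-1 to 22 mL.min-1.g-1).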

Compound 4, intrinsic clearance in microsomes: < 7 mL.min-1.g-1
Compound 4: no number, only a limit; the forecaster's own chance of this, stated with the estimate: 30%; at least 1.2-fold (0.10 log units) between middle value and limit.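

Replacing piperidin-4-yl with 3-((4-hydroxycyclohexyl)amino)propyl on the oxygen gives an at least 2.1-fold lower number from compound 3 to compound 4 (0.33 log units; beyond the scatter) in this assay, and the comparison with the 4-hydroxypiperidin-4-yl side chain gives an at least 2.2-fold lower number from compound 1 to compound 4 (0.35 log units; beyond the scatter). A reading at the limit on this oxygen is therefore no longer tied to a side chain ending in piperidin-4-yl. Compound 4 gives only a limit, and the step from compound 2 to compound 4 cannot be read: the limit of < 7 mL.min-1.g-1 in this assay, at which 2 of the 4 values shown sit.

Among the compounds shown, the propyl chain and the 4-hydroxycyclohexyl ring change together, so neither can be singled out. A longer butyl chain or a plain cyclohexylamine would help to separate them.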